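The source may hold more compounds than are shown below. What is called first, only, known or untested is meant among the compounds shown, and "the series" means these compounds.

Within the data shown here, compound 1, `NC(=O)CCCCc1c[nH]c2ccc(F)cc12`, has been measured in an assay on isolated protein for inhibition of Myeloperoxidase (Homo sapiens), read by ELISA, with a stated time of 5 min (a lower number here means a stronger inhibitor, a higher number a weaker inhibitor), and gives 43 nM, the highest of the two numbers known so far. Among the measured compounds shown here, the only other measured compound, compound 2, `NCCCCc1c[nH]c2c(F)cccc12`, gives 21 nM in this assay, a number that lies beyond the usual scatter below that of compound 1. For the measured compounds named here, no pair of measured compounds differing in a single place is available, so the step considered here has no direct anchor in a measured comparison. Compound 3, `ONCCCc1c[nH]c2ccc(F)cc12`, remains to be measured in this assay. It differs from compound 1 in one place: hydroxyamino in place of carbamoylmethyl on a saturated chain carbon, three bonds along the chain from an aromatic carbon. Relative to compound 1, the number for compound 3 is expected to fall, the step of a 2.9-fold lower number from compound 1 to compound 3 (0.46 log units; beyond the scatter) being moderate yet beyond the scatter. This expectation rests only on the two known values, with compound 2 giving 21 nM as the nearer reference point. Compound 3 is therefore estimated at 15 nM, with a likely range from 4 nM to 60 nM.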

Compound 3, half-maximal inhibitory concentration: 21 nM
For compound 3 the middle estimate is 1.4-fold (0.15 log units) below the measured one; the measured number falls inside the stated range.
By their numbers in this assay, from the lowest: compounds 2 and 3 (each within the scatter of the next); then compound 1.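

In this assay, among these compounds, this change gives the first step that can be read between two compounds differing in one place: a 2.0-fold lower number from compound 1 to compound 3 (0.31 log units; beyond the scatter). On a saturated chain carbon, three bonds along the chain from an aromatic carbon, hydroxyamino therefore gives stronger inhibition than carbamoylmethyl, so the carbonyl of the group that leaves is not needed at this position to reach this level of inhibition. The entering group has 2 heavy atoms where the leaving group has 4, and 2 hydrogen-bond donors where the leaving group has 1, but no measurement here links either difference to the lower number.

This single step changes both the size and the make-up of the group, so it cannot show which of the two matters, and the same difference can also be read as 2-carbamoylethyl to (hydroxyamino)methyl. A methoxyamino group or a carboxylic acid at the same place, or hydroxyamino on a longer chain, would help to separate these readings and show how far the gain extends.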